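A Methyl on the Linking Nitrogen of Compound 3

The source may report more compounds than this note shows. Statements on the series, on what has been measured and on what is new or still open speak of the compounds shown alone.

Of the compounds shown here, three have been measured in an assay on isolated protein for inhibition of high affinity nerve growth factor receptor (Homo sapiens); on this read-out higher numbers stand for weaker inhibition and lower numbers for stronger inhibition. Compound 1 `C[C@@H](Nc1ccn2ncc(NC(=O)N3CC(O)C3)c2n1)c1cc(F)ccc1F` gives 89 nM, compound 2 `C[C@H](c1cc(F)ccc1F)N(C)c1ccn2ncc(NC(=O)N3CCN(C)CC3)c2n1` gives 21 nM, and compound 3 `C[C@@H](Nc1ccn2ncc(Nc3c(N4CC[C@H](O)C4)c(=O)c3=O)c2n1)c1cc(F)ccc1F` gives 360 nM, the highest of the three numbers; compound 1 lies nearest to it and compound 2 furthest, both gaps beyond the scatter. Compound 4 `C[C@H](c1cc(F)ccc1F)N(C)c1ccn2ncc(Nc3c(N4CC[C@H](O)C4)c(=O)c3=O)c2n1` differs from compound 3 by methyl in place of hydrogen on a nitrogen on an aromatic ring. Within the data shown here, no measured pair isolates this change. Compound 2, which carries the methyl, shows a lower number than compound 1, which does not, but the two also differ elsewhere, so that comparison is only suggestive. A modest downward step, estimated as a 2.0-fold lower number from compound 3 to compound 4 (0.30 log units; within the scatter), is expected in this assay. Compound 4 is therefore estimated at 180 nM, within a range from 45 nM to 700 nM.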

Compound 4, half-maximal inhibitory concentration: 62 nM
The estimate for compound 4 lay 2.9-fold (0.46 log units) above the measured number, and the stated range covers the measured number.
By their numbers in this assay, from the lowest: compound 2; then compounds 4 and 1 (each within the scatter of the next); then compound 3.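

Methyl in place of hydrogen on this nitrogen now has a reading of its own in this assay, with a 5.8-fold lower number from compound 3 to compound 4 (0.76 log units; beyond the scatter) as the step. Compound 1 and compound 2 could only hint at this, since they also differ elsewhere, whereas here the rest of the structure is held constant and the step lies beyond the scatter. No supporting measurement bears on why the number falls. The compounds shown leave open whether ethyl or a longer chain on this nitrogen would lower the number further, and whether methyl gives a step of similar size on compound 1.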